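This account rests on a few compounds, and the source may have more. Where it says the series, first, only, none or still open, it means among the compounds named here.

Of the compounds shown here, three sharing one core have been tested in a functional assay on MCF7 cells (Homo sapiens) for antiproliferative activity, read by MTT assay, with a stated time of 72 h; on this read-out higher numbers stand for weaker inhibition and lower numbers for stronger inhibition. Compound 1 `Cc1cc(N(C)C)nc2ccc(NC(=O)c3ccc(Cl)c(Cl)c3)cc12` gives 33300 nM, compound 3 `Cc1cc(N2CCN(C)CC2)nc2ccc(NC(=O)c3ccc(Cl)c(Cl)c3)cc12` gives 3000 nM, and compound 2 `CCN1CCN(c2cc(C)c3cc(NC(=O)c4cccc(F)c4)ccc3n2)CC1` gives 8920 nM. Among the compounds with values here, the single measured change in one place, an 11-fold lower number from compound 1 to compound 3 (1.05 log units; beyond the scatter), sits on the core rather than on the amide part. Compound 2 stands second highest of the three numbers, between compound 3 and compound 1. Compound 4 `CCN1CCN(c2cc(C)c3cc(NC(=O)c4ccccc4)ccc3n2)CC1` differs from compound 2 in one place: hydrogen in place of fluoro on an aromatic carbon. Within the data shown here, no measured step touches this part of the molecule; the one known step concerns a different place. A step of no size beyond the scatter is expected, and compound 4 is estimated at 10000 nM, within 4000 nM to 25000 nM, which means an expected 1.1-fold higher number from compound 2 to compound 4 (0.05 log units; within the scatter).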

Compound 4, half-maximal inhibitory concentration: 14200 nM
Estimate against measurement, compound 4: 1.4-fold (0.15 log units) below; the range from low to high includes it.
By their numbers in this assay, from the lowest: compound 3; then compounds 2 and 4 (each within the scatter of the next); then compound 1.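

Swapping the fluoro for hydrogen on an aromatic carbon of the amide part gives a 1.6-fold higher number from compound 2 to compound 4 (0.20 log units; within the scatter) and so stays within the scatter. Within the data shown here, the only earlier step sat on the core, so this is the first measured look at the amide part, and here the single fluorine atom can go with no readable gain or loss. Nothing available explains this outcome. Going by these compounds, what a larger group at this place, such as methoxy, trifluoromethyl or an amine, would do remains open. So does whether the same swap would stay as quiet with a different group on the core.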